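The source may hold more compounds than are shown below. What is called first, only, known or untested is meant among the compounds shown, and "the series" means these compounds.

Three compounds share one core and differ only in the group carried on an amine nitrogen in a ring. Compound 1 `CC(C)(C)OC(=O)N1CCC(O[C@H]2CC[C@H](Oc3cnc(S(C)(=O)=O)cn3)CC2)CC1` gives 110% in a functional assay on isolated protein for agonist activity at Glucose-dependent insulinotropic receptor (Rattus norvegicus), read by HTRF and cAMP accumulation; a lower number here means a smaller maximal response, a higher number a larger maximal response. Compound 2 `CC(C)OC(=O)N1CCC(O[C@H]2CC[C@H](Oc3cnc(S(C)(=O)=O)cn3)CC2)CC1` gives 120% in this assay. Compound 3 `CS(=O)(=O)c1cnc(O[C@H]2CC[C@H](OC3CCN(C(=O)Oc4ccccc4)CC3)CC2)cn1` gives 104% in this assay. Among these three numbers compound 3 stands lowest: compound 1 sits within the scatter of it, while compound 2 lies furthest away, beyond the scatter. The measured steps are a number 10 percentage points higher from compound 1 to compound 2 (within the scatter), a number 6 percentage points lower from compound 1 to compound 3 (within the scatter) and a number 16 percentage points lower from compound 2 to compound 3 (beyond the scatter).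

Compound 4 `CS(=O)(=O)c1cnc(O[C@H]2CC[C@H](OC3CCN(CC4(C(F)(F)F)CCC4)CC3)CC2)cn1` differs from compound 3 by (1-(trifluoromethyl)cyclobutyl)methyl in place of phenoxycarbonyl on an amine nitrogen in a ring

For the measured compounds named here, none of the measured steps bears directly on this change. Each of them exchanges the group on the oxygen next to a carbonyl group, whereas here the whole phenoxycarbonyl leaves and a (1-(trifluoromethyl)cyclobutyl)methyl enters on the amine nitrogen in a ring. All that the measured compounds show is that the maximal response stayed close to the reference throughout, with the largest step only modest. The expectation is therefore a step of no clear direction, estimated as a number 1 percentage points higher from compound 3 to compound 4 (within the scatter), with wide uncertainty. Compound 4 is expected to give 105% in this assay, estimated between 80% and 130%.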

Compound 4, largest response reached (Emax), in percent of the reference or control that the assay uses: 99%
Compound 4: the middle estimate sits 6 percentage points above what was measured; the range from low to high includes it.
By their numbers in this assay, from the lowest: compounds 4, 3, 1 and 2 (each within the scatter of the next, the first and the last beyond it).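

Compound 4 shows that the amine nitrogen in a ring can carry a group with no carbonyl and still give a response close to the reference in this assay: exchanging phenoxycarbonyl for (1-(trifluoromethyl)cyclobutyl)methyl gives a number 5 percentage points lower from compound 3 to compound 4 (within the scatter) even though the aromatic ring, the double bond and the hydrogen-bond acceptors of the leaving group are all gone. Against the other two groups on this nitrogen the picture differs, with a number 21 percentage points lower from compound 2 to compound 4 (beyond the scatter) when isopropoxycarbonyl is replaced and a number 11 percentage points lower from compound 1 to compound 4 (beyond the scatter) when tert-butoxycarbonyl is replaced, so the new group costs a modest part of the maximal response relative to those two, but not relative to phenoxycarbonyl. No separate measurement is available here to link these steps to any property of the groups.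

The compounds shown leave open whether the trifluoromethyl or the four-membered ring matters more on this nitrogen, a question that a plain cyclobutylmethyl group would address. They also leave open how a benzyl group or an acetyl group on the same nitrogen would compare.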